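Urea-pyrazole series: demethylation step on the chloromethoxyphenyl arm

The compounds below may be only part of what the source reports. "The series", "measured", "known", "first", "only" and "open" are said of these compounds alone.

Measured so far:
compound 1, `COc1cc(-c2nn(-c3cccc(NC(=O)Nc4cc(C(F)(F)F)cc(C(F)(F)F)c4)c3)cc2-c2ccncc2)ccc1Cl`, 307 nM
compound 2, `COc1cc(-c2nn(-c3cccc(NC(=O)Nc4ccc(Cl)c(Cl)c4)c3)cc2-c2ccncc2)ccc1Cl`, 567 nM
compound 3, `O=C(Nc1cccc(-n2cc(-c3ccncc3)c(-c3ccc(Cl)c(O)c3)n2)c1)Nc1ccc(Cl)c(Cl)c1`, 729 nM

All three were run in a functional assay on MDA-MB-468 cells (Homo sapiens) for inhibition, read by sulforhodamine B assay, with a stated time of 48 h; on this read-out lower numbers stand for stronger inhibition of growth and higher numbers for weaker inhibition of growth. Compound 1 gives the lowest of the three numbers; its gap to compound 2 stays within the scatter, while its gap to compound 3 lies beyond it. The difference between the core of compound 1 and the core of compound 2 is not broken down here.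

One change is seen twice. From compound 2 to compound 3 it reads (hydrogen in place of methyl on an oxygen on an aromatic ring), and in this assay it made a 1.3-fold higher number from compound 2 to compound 3 (0.11 log units; within the scatter). From compound 1 to the as yet unmeasured compound 4, `O=C(Nc1cccc(-n2cc(-c3ccncc3)c(-c3ccc(Cl)c(O)c3)n2)c1)Nc1cc(C(F)(F)F)cc(C(F)(F)F)c1`, the same change reads (hydrogen in place of methyl on an oxygen on an aromatic ring); the place lines of the two changes agree word for word, so this is the same change, not merely the same kind.

On that basis, compound 4 is expected to sit close to compound 1, a step of about a 1.3-fold higher number from compound 1 to compound 4 (0.11 log units; within the scatter), because a 1.3-fold higher number from compound 2 to compound 3 (0.11 log units; within the scatter) stayed within the scatter. The estimated value for compound 4 in this assay is 400 nM, with the expected range running from 200 nM to 800 nM.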

Compound 4, concentration for 50% growth inhibition: 265 nM
The estimate for compound 4 lay 1.5-fold (0.18 log units) above the measured number; measured number inside the range.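

In this assay, the change from methoxy to hydroxy on the chlorinated arm gave a 1.2-fold lower number from compound 1 to compound 4 (0.06 log units; within the scatter), a small step on this second core. Set beside the earlier step, the result gives no sign that the core alters the outcome of this change, and for these two cores a hydroxy can stand in for the methoxy with no step beyond the scatter: the same change on two cores in this assay, a 1.3-fold higher number (0.11 log units; within the scatter) from compound 2 to compound 3 and a 1.2-fold lower number (0.06 log units; within the scatter) from compound 1 to compound 4, 1.5-fold (0.17 log units) apart, within the scatter of two such steps. This does not establish a direction for the change, since the two steps point opposite ways within the scatter, and it says nothing about cores other than these two, or about why the steps are small.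

Still open, as far as these compounds go, is whether the same holds when the oxygen carries a longer chain such as ethyl, or when an amine takes the place of the hydroxy. Also open, from the compounds shown here alone, is whether the step stays this small on a core whose urea arm is a plain phenyl, with neither chloro nor trifluoromethyl groups.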